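The compounds below may be only part of what the source reports. "The series", "measured", "known", "first", "only" and "open" are said of these compounds alone.

In a toxicity assay on L02 cells (Homo sapiens) for cytotoxicity, read by MTT assay, with a stated time of 24 h (on this read-out higher numbers stand for lower toxicity in this test and lower numbers for higher toxicity in this test), compound 3 `CCCCS(=O)(=O)Oc1ccc(/C=C/C(=O)OCC(C)C)cc1OC` gives 63800 nM. Compound 1 `CCCCS(=O)(=O)Oc1ccc(/C=C/C(=O)Nc2cccc(C)c2)cc1OC` gives 33600 nM, and compound 2 `CCCCS(=O)(=O)Oc1ccc(/C=C/C(=O)Nc2ccccc2)cc1OC` gives 3320 nM. Compound 3 thus sits level with compound 1, a 1.9-fold higher number from compound 1 to compound 3 (0.28 log units; within the scatter), and well clear of compound 2, a 19-fold higher number from compound 2 to compound 3 (1.28 log units; beyond the scatter). Compound 4 `CCCCOC(=O)/C=C/c1ccc(OS(=O)(=O)CCCC)c(OC)c1`, not yet measured, has the same atoms as compound 3, joined differently: propyl in place of isopropyl on a saturated chain carbon bound to an oxygen next to a carbonyl group, so isobutoxy becomes butoxy. Among the compounds with values here, no measured step makes this exact change. Those two steps swap whole groups on the carbonyl carbon, so they bear only loosely. The closest in size, a 10-fold lower number from compound 1 to compound 2 (1.01 log units; beyond the scatter), shows that a small edit can still count. Even so, nothing beyond the scatter is expected in this assay, and the direction stays open. The expected step is a 1.1-fold lower number from compound 3 to compound 4 (0.03 log units; within the scatter). For compound 4 the estimated value is 60000 nM, with an expected range of 20000 nM to 140000 nM.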

Compound 4, half-maximal cytotoxic concentration: 115000 nM
Compound 4: the middle estimate sits 1.9-fold (0.28 log units) below what was measured; measured number inside the range.
By their numbers in this assay, from the lowest: compound 2; then compounds 1, 3 and 4 (each within the scatter of the next, the first and the last beyond it).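

In this assay, turning isopropyl into propyl at this position makes no difference beyond the scatter, a 1.8-fold higher number from compound 3 to compound 4 (0.26 log units; within the scatter), the first direct test of this rearrangement. Butoxy on the carbonyl carbon stands well apart from anilino, a 35-fold higher number from compound 2 to compound 4 (1.54 log units; beyond the scatter), and, unlike isobutoxy, also clears the scatter against (3-methylphenyl)amino, a 3.4-fold higher number from compound 1 to compound 4 (0.53 log units; beyond the scatter). Nothing available explains these steps. Going by these compounds, whether a longer chain on that oxygen would keep the number in the same range stays open. So does what a carboxylic acid on the carbonyl carbon would give.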